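This account rests on a few compounds, and the source may have more. Where it says the series, first, only, none or still open, it means among the compounds named here.

Of the compounds shown here, three sharing one core have been measured in an ADME assay on brain (Rattus norvegicus) for protein binding; on this read-out lower numbers stand for a smaller free fraction and higher numbers for a larger free fraction. Here compound 1 `O=C1O[C@]2(CC[C@H](CNc3cnn(-c4ccccc4F)c3)CC2)CN1c1cncnc1` gives 0.044, compound 2 `O=C1O[C@]2(CC[C@H](CNc3cnn(-c4ccccc4F)c3)CC2)CN1c1cccnc1` gives 0.025 and compound 3 `O=C1O[C@]2(CC[C@H](CNc3cnn(-c4ccccc4F)c3)CC2)CN1c1ccnnc1` gives 0.044. Compound 3 therefore matches compound 1 at the digits shown, and all three values lie within the scatter of one another. Only the ring on the amide-type nitrogen differs among them, and the swaps made there are small: no change at the digits printed from compound 1 to compound 3 (within the scatter), and a 1.8-fold higher number from compound 2 to compound 3 (0.25 log units; within the scatter).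

Compound 4 `O=C1O[C@]2(CC[C@H](CNc3cnn(-c4ccccc4F)c3)CC2)CN1c1cccnc1F` changes the same place, with 2-fluoropyridin-3-yl in place of pyridazin-4-yl on an amide-type nitrogen in a ring. Going by the values given here, no measured compound carries a fluorine on this ring, so its contribution is unknown. The nearest guide is compound 2, which has pyridin-3-yl and gives 0.025. A small downward step is therefore expected, within the scatter. The estimated change is a 1.8-fold lower number from compound 3 to compound 4 (0.26 log units; within the scatter). For compound 4, the expected value is 0.024, with an estimated range from 0.013 to 0.042.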

Compound 4, unbound fraction: 0.019
For compound 4 the middle estimate is 1.3-fold (0.10 log units) above the measured one; measured number inside the range.
By their numbers in this assay, from the lowest: compounds 4, 2, 1 and 3 (each within the scatter of the next, the first and the last beyond it).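

In this assay this position now gives steps beyond the scatter, though modest ones: the 2-fluoropyridin-3-yl ring gives a 2.3-fold lower number from compound 3 to compound 4 (0.36 log units; beyond the scatter) and also a 2.3-fold lower number from compound 1 to compound 4 (0.36 log units; beyond the scatter) when the pyrimidin-5-yl ring is the starting point. The closest comparison isolates the fluorine, and fluoro in place of hydrogen on an aromatic carbon gives only a 1.3-fold lower number from compound 2 to compound 4 (0.12 log units; within the scatter), so the fluorine alone cannot be told apart from repeat-measurement noise, and the larger steps involve a change of the ring itself as well. Nothing available here explains these differences.

As far as these compounds go, it remains open how a plain phenyl ring, with no ring nitrogen, would compare on this amide-type nitrogen. From the compounds shown here alone, the effect of chloro or methoxy in place of fluoro on the pyridin-3-yl ring is equally open.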